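This account rests on a few compounds, and the source may have more. Where it says the series, first, only, none or still open, it means among the compounds named here.

Measured in a functional assay on MDA-MB-231 cells (Homo sapiens) for cytotoxicity, read by MTT assay, with a stated time of 72 h; on this read-out higher numbers stand for weaker inhibition and lower numbers for stronger inhibition:
- compound 1 `O=C(CN1CCN(c2nnc(Cc3ccncc3)c3ccccc23)CC1)Nc1cccc(Br)c1`: 1.7 nM
- compound 2 `O=C(CN1CCN(c2nnc(Cc3ccncc3)c3ccccc23)CC1)Nc1cccc(F)c1`: 4.4 nM
- compound 3 `O=C(CN1CCN(c2nnc(Cc3ccncc3)c3ccccc23)CC1)Nc1ccc(F)c(C(F)(F)F)c1`: 1.9 nM

Compound 2, at 4.4 nM, has the highest number of the three, which means the weakest inhibition among them. Compound 4 `O=C(CN1CCN(c2nnc(Cc3ccccc3)c3ccccc23)CC1)Nc1cccc(F)c1` differs from it as follows: phenyl in place of pyridin-4-yl on a saturated chain carbon bound to an aromatic carbon. Within the data shown here, none of the measured steps touches this group, so they offer only indirect guidance. Two were modest, a 2.6-fold higher number from compound 1 to compound 2 (0.41 log units; beyond the scatter) and a 2.3-fold lower number from compound 2 to compound 3 (0.36 log units; beyond the scatter), while a 1.1-fold higher number from compound 1 to compound 3 (0.05 log units; within the scatter) was smaller still. The data give no direction for the swap of pyridin-4-yl for phenyl, so no step beyond the scatter is expected in this assay. The expected result is a 1.1-fold higher number from compound 2 to compound 4 (0.06 log units; within the scatter). For compound 4 the estimated value is 5 nM, with an expected range from 1.5 nM to 20 nM.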

Compound 4, half-maximal inhibitory concentration: 3730 nM
For compound 4 the middle estimate is 750-fold (2.87 log units) below the measured one; measured number outside the range, above it.
By their numbers in this assay, from the lowest: compounds 1 and 3 (each within the scatter of the next); then compound 2; then compound 4.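

In this assay, among these compounds, the group on the saturated chain carbon bound to an aromatic carbon matters far more than the earlier amide-side changes suggested: phenyl in place of pyridin-4-yl gives an 850-fold higher number from compound 2 to compound 4 (2.93 log units; beyond the scatter), with only one ring nitrogen exchanged for carbon. So a change of a single ring atom at this place can separate a very strong inhibitor from a much weaker one. No measurement shown explains this loss.

From the compounds shown here alone, whether the position of the ring nitrogen matters remains open, as a pyridin-3-yl or pyridin-2-yl group would show. Going by these compounds, it is also open whether a pyrimidinyl ring could serve here.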